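The source may hold more compounds than are shown below. What is called first, only, known or untested is meant among the compounds shown, and "the series" means these compounds.

Measured so far in an ADME assay on PANC-1 cells (Homo sapiens) for cytotoxicity, read by sulforhodamine B assay, with a stated time of 48 h, tested at 10 uM; a lower number here means less inhibition, a higher number more inhibition at the concentration tested (going by the name of the read-out):
compound 1 `CCOC(=O)c1cn(C(c2ccccc2)c2cc3cc(Br)ccc3nc2OC)nn1` — 15.4%
compound 2 `COc1nc2ccc(Br)cc2cc1C(c1ccccc1)n1cc(-c2ccc(F)cc2)nn1` — 14.9%

Compound 2 sits at the lower of the two numbers in this assay, but its distance to compound 1, a number 0.5 percentage points lower from compound 1 to compound 2 (within the scatter), is within the scatter, so the two compounds cannot be told apart on these data.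

Compound 3 `COc1nc2ccc(Br)cc2cc1C(c1ccccc1)n1cc(CCCCCO)nn1` is the next compound to be measured. Its difference from compound 2 is 5-hydroxypentyl in place of 4-fluorophenyl on an aromatic carbon.

Going by the values given here, only one measured step touches the same position: a number 0.5 percentage points lower from compound 1 to compound 2 (within the scatter), where a 4-fluorophenyl replaced an ethoxycarbonyl and the number did not move beyond the scatter. Among the compounds with values here, no measured compound carries a 5-hydroxypentyl group, so nothing directly shows what this group does in this assay. Given that the one exchange at this position left the read-out flat, the expected step of a number 0.9 percentage points lower from compound 2 to compound 3 (within the scatter) from compound 2 to compound 3 is small and in no particular direction, not beyond the scatter.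

Compound 3 is therefore estimated at 14% in this assay, with a range of 4% to 27%.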

Compound 3, a percentage reported as inhibition, at one concentration (the size of the read-out at that concentration, not a potency): 19.6%
For compound 3 the middle estimate is 5.6 percentage points below the measured one; the range from low to high includes it.
By their numbers in this assay, from the lowest: compounds 2, 1 and 3 (each within the scatter of the next).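

At the aromatic carbon of the five-membered aromatic ring with 3 nitrogen, this assay now covers an open chain as well as the two earlier groups: the exchange of 4-fluorophenyl for 5-hydroxypentyl gives a number 4.7 percentage points higher from compound 2 to compound 3 (within the scatter) and the exchange of ethoxycarbonyl for 5-hydroxypentyl gives a number 4.2 percentage points higher from compound 1 to compound 3 (within the scatter) and both steps lie within the scatter. Losing the six-membered aromatic ring of carbon only and gaining a chain with no ring, 1 hydrogen-bond donor and 1 hydrogen-bond acceptor therefore does not separate compound 3 from compound 1 or compound 2, so this position has now taken three quite different groups without a step beyond the scatter. No supporting measurement bears on these numbers, and they stay without an explanation.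

From the compounds shown here alone, whether an amine, a carboxylic acid or a longer chain ending in a hydroxyl group at this position would give a step beyond the scatter remains open. Also open, going by these compounds, is how these compounds would compare at other concentrations, since a single-concentration read-out gives no potency.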